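Swapping Methoxy for Chloro on the Benzyl Ring

The source may report more compounds than this note shows. Statements on the series, on what has been measured and on what is new or still open speak of the compounds shown alone.

Compound 3 `COc1ccc(COc2ccc(-c3nn(CCC#N)c(=S)o3)cc2)cc1` gives the lowest of the three numbers recorded in an assay for inhibition of Amine oxidase [flavin-containing] A (Rattus norvegicus) (on this read-out lower numbers stand for stronger inhibition and higher numbers for weaker inhibition), at 4800 nM. Its nearest neighbour, compound 2 `N#CCCn1nc(-c2ccc(OCc3ccc([N+](=O)[O-])cc3)cc2)oc1=O`, gives 11000 nM in this assay, and compound 1 `Cc1cccc(COc2ccc(-c3nn(CCC#N)c(=O)o3)cc2)c1` gives 20000 nM, both gaps lying beyond the scatter. Compound 4 `N#CCCn1nc(-c2ccc(OCc3ccc(Cl)cc3)cc2)oc1=S` has not yet been measured. It differs from compound 3 in one place: chloro in place of methoxy on an aromatic carbon.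

Among the measured compounds shown here, only one measured step joins compounds that differ in a single place, a 1.8-fold lower number from compound 1 to compound 2 (0.26 log units; within the scatter), and it concerns the same benzyl ring: one group was exchanged for another there, yet the number barely moved. For the measured compounds named here, no measured step exchanges methoxy for chloro, and compound 3 differs from both compound 1 and compound 2 in more than one place, so no single-place step reaches it. Going by the values given here, the evidence in hand therefore gives no reason to expect a step beyond the scatter in this assay, though the uncertainty is wide because the one recorded swap on this ring is a different exchange. The expected step is a 1.1-fold lower number from compound 3 to compound 4 (0.03 log units; within the scatter). Compound 4 is accordingly estimated at 4500 nM, with a range from 1500 nM to 13000 nM.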

Compound 4, half-maximal inhibitory concentration: 2700 nM
For compound 4 the middle estimate is 1.7-fold (0.22 log units) above the measured one; measured number inside the range.
By their numbers in this assay, from the lowest: compounds 4 and 3 (each within the scatter of the next); then compounds 2 and 1 (each within the scatter of the next).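

In this assay the exchange of 4-methoxyphenyl for 4-chlorophenyl gives a 1.8-fold lower number from compound 3 to compound 4 (0.25 log units; within the scatter), so this place on an aromatic carbon, para to a large group, accepts the loss of the methoxy oxygen and the arrival of a chlorine without a step beyond the scatter. Among the compounds shown here, this is the first measured exchange between two groups at one and the same place on this ring, and it joins a 1.8-fold lower number from compound 1 to compound 2 (0.26 log units; within the scatter), which also stays within the scatter, so both single-place steps on the benzyl ring are small, though only these two exchanges are known. No measurement at hand accounts for the small size of the step, and nothing can be said about its cause.

Going by these compounds, how an amine or a carboxylic acid at this place would read in this assay remains open, since methoxy and chloro span only a narrow set of groups. Also open, on these data alone, is whether the exchange of methoxy for chloro would give a step of similar size on the core of compound 1, which carries a carbonyl where compound 3 carries sulfur.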